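The compounds below may be only part of what the source reports. "The series", "measured", "known", "first", "only" and "open" are said of these compounds alone.

Working notes on the series. Compound 1 `COC(=O)c1cc(-c2cccc(NC(=O)c3ccc(/C=C/C(=O)c4cc(F)ccc4F)cc3)c2)on1` carries a 2,5-difluorophenyl on a carbonyl carbon whose other neighbour is a double-bonded chain carbon. In an ADME assay on Vero cells (Chlorocebus sabaeus) for cytotoxicity, read by MTT assay, with a stated time of 72 h (on this read-out lower numbers stand for higher toxicity in this test and higher numbers for lower toxicity in this test), compound 1 gives > 40 ug/mL, which is a limit of the assay and not a number. Compound 1 therefore sits at the limit of > 40 ug/mL in this assay, at which 1 of the 2 values shown sits. Compound 2 `CCCOc1ccc(C(=O)/C=C/c2ccc(C(=O)O)cc2)cc1` is the second measured member. In this assay compound 2 gives < 10 ug/mL, again a limit and not a number. Compound 2 sits at the limit of < 10 ug/mL in this assay, at which 1 of the 2 values shown sits. Within the data shown here, no step between measured compounds that differ in one place is available, so the two values show only where each compound sits. Among the measured compounds shown here, compound 3 `COC(=O)c1cc(-c2cccc(NC(=O)c3ccc(/C=C/C(=O)c4ccc(C)c([N+](=O)[O-])c4)cc3)c2)on1` is not yet measured. 4-methyl-3-nitrophenyl in place of 2,5-difluorophenyl on a carbonyl carbon No measured compound carries the entering group, so the change is untested here. The step of a number no higher from compound 1 to compound 3 (the limit leaves the size open) is expected to be none beyond the scatter. Compound 3 is expected to give 40 ug/mL in this assay, with a range from 15 ug/mL to 80 ug/mL.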

Compound 3, half-maximal cytotoxic concentration: > 80 ug/mL
Compound 3 ended at the assay's limit (the forecaster's own chance of this, stated with the estimate: 60%); at least 2.0-fold (0.30 log units) between middle value and limit.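

Among these compounds, compound 1 and compound 3 both stand at limits of this assay, so no step between them can be read. The compounds shown leave open the size and direction of any change from 4-methyl-3-nitrophenyl in place of 2,5-difluorophenyl on a carbonyl carbon.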